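Shortening the Hydroxamate Chain on Two Related Cores

This account rests on a few compounds, and the source may have more. Where it says the series, first, only, none or still open, it means among the compounds named here.

Compound 1 `Nc1ncnc2c1c(-c1cnc3[nH]ccc3c1)nn2CCCCCC(=O)NO` and compound 2 `Nc1ncnc2c1c(-c1cnc3[nH]ccc3c1)nn2CCCCCCCCCC(=O)NO` share one core, while compound 3 `Nc1nc2cc(-c3nn(CCCCCC(=O)NO)c4ncnc(N)c34)ccc2o1` and the still unmeasured compound 4 `Nc1nc2cc(-c3nn(CC(=O)NO)c4ncnc(N)c34)ccc2o1` share another; the difference between the two cores is not broken down here. In a functional assay on HCT-116 cells (Homo sapiens) for inhibition, read by MTT assay, with a stated time of 72 h (a higher number here means a weaker inhibitor, a lower number a stronger inhibitor), compound 2 gives 18700 nM and compound 1 gives 63700 nM, while compound 3 gives 21500 nM. The change from compound 2 to compound 1 is hydroxycarbamoyl in place of 4-(hydroxycarbamoyl)butyl on a saturated chain carbon, five bonds along the chain from an aromatic nitrogen, and it brought a 3.4-fold higher number from compound 2 to compound 1 (0.53 log units; beyond the scatter). Compound 4 differs from compound 3 by the same kind of change, (hydroxycarbamoyl in place of 4-(hydroxycarbamoyl)butyl on a saturated chain carbon bound to an aromatic nitrogen), though the place is not identical: in compound 3 the saturated chain carbon is bound to an aromatic nitrogen rather than five bonds along the chain from it. Because compound 1 weakened to 63700 nM after that shortening, a similar weakening is expected for compound 4, a 3.3-fold higher number from compound 3 to compound 4 (0.51 log units; beyond the scatter). Compound 4 is estimated at 70000 nM, expected between 30000 nM and 200000 nM.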

Compound 4, half-maximal inhibitory concentration: 11400 nM
Compound 4: the middle estimate sits 6.1-fold (0.79 log units) above what was measured, outside the stated range (below it).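

In this assay, putting hydroxycarbamoyl in place of 4-(hydroxycarbamoyl)butyl gave a 1.9-fold lower number from compound 3 to compound 4 (0.28 log units; within the scatter), so on this core the two chains cannot be told apart. The change therefore did not carry over from one core to the other: the same change on two cores in this assay, a 3.4-fold higher number (0.53 log units; beyond the scatter) from compound 2 to compound 1 and a 1.9-fold lower number (0.28 log units; within the scatter) from compound 3 to compound 4, 6.4-fold (0.81 log units) apart, beyond the scatter of two such steps. This shows that the step on one core is a poor guide to the step on the other, but with a single pair per core, and the change sitting at a different place on the chain in each pair, it does not show what causes the gap.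

The compounds shown leave open how a longer chain would read on the core of compound 3. They also leave open whether a carboxylic acid in place of the hydroxycarbamoyl end would keep any of this activity.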